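A few compounds are considered here, and "the series" means these few. Any claim that something is new, unique, unknown or untested is made for them only; others in the source may bear on it.

Compounds measured so far:
Compound 1, `Cc1cccc(-n2nncc2CN2C(=O)C3(C(C#N)=C(N)Oc4c3c3nc5ccccc5nc3c3ccccc43)c3ccccc32)c1`, in a functional assay on HCT-116 cells (Homo sapiens) for antiproliferative activity, read by MTT assay, with a stated time of 48 h (on this read-out higher numbers stand for weaker inhibition and lower numbers for stronger inhibition), gives > 50000 nM, a limit of the assay rather than a number.
Compound 2, `N#CC1=C(N)Oc2c(c3nc4ccccc4nc3c3ccccc23)C12C(=O)N(Cc1cnnn1-c1cccc(Cl)c1)c1ccccc12`, in this assay gives > 50000 nM, again a limit.
Compound 3, `N#CC1=C(N)Oc2c(c3nc4ccccc4nc3c3ccccc23)C12C(=O)N(Cc1cnnn1-c1ccc(S(N)(=O)=O)cc1)c1ccccc12`, in this assay gives 31200 nM.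

Compound 1 therefore sits at the limit of > 50000 nM in this assay, at which 2 of the 3 values shown sit. Only compound 3 returns an actual number, and even that is a weak one.

Compound 4, `Cc1ccc(-n2nncc2CN2C(=O)C3(C(C#N)=C(N)Oc4c3c3nc5ccccc5nc3c3ccccc43)c3ccccc32)cc1C`, differs from compound 1 by methyl in place of hydrogen on an aromatic carbon. Every measured step concerns the aryl group on the triazole nitrogen rather than a methyl added to the ring already present: a step that the two limits leave unreadable from compound 1 to compound 2, an at least 1.6-fold lower number from compound 1 to compound 3 (0.20 log units; that floor lies within the scatter) and an at least 1.6-fold lower number from compound 2 to compound 3 (0.20 log units; that floor lies within the scatter). Among the compounds with values here, none of them bears directly on the change from compound 1 to compound 4, and the only readable steps, those into compound 3, reach just a floor that lies within the scatter. With compound 1 at a limit and small aryl changes moving nothing clearly, a small methyl is expected to leave the read-out where it is, with no step beyond the scatter: a step that the limit leaves unreadable from compound 1 to compound 4. Compound 4 is thus estimated at 70000 nM, within a range from 25000 nM to 200000 nM, most likely reported again as a limit.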

Compound 4, half-maximal inhibitory concentration: > 50000 nM
Compound 4 ended at the assay's limit; the forecaster's own chance of this, stated with the estimate: 75%; the middle value does not contradict the limit.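

The added methyl sits on an aromatic carbon, ortho to a methyl group and para to a large group, and turning 3-methylphenyl into 3,4-dimethylphenyl brings no measurable number into the series, so compound 4 stays at the limit with the others: the limit of > 50000 nM in this assay, at which 3 of the 4 values shown sit. The steps from compound 1 and from compound 2 to compound 4 join two limits and cannot be read. Within the data shown here, the only readable step is an at least 1.6-fold higher number from compound 3 to compound 4 (0.20 log units; that floor lies within the scatter), so 3,4-dimethylphenyl in place of 4-sulfamoylphenyl on the aromatic nitrogen gives no firm separation between compound 3 and compound 4, only a floor.

The limits leave open how far apart compound 1, compound 2 and compound 4 really lie, since any of them could sit just past the limit or far beyond it. Also open, as far as these compounds go, is whether an amine or a carboxylic acid on this phenyl ring, or a longer chain such as propyl in place of the added methyl, would give a true number in this assay and a step that clears the scatter.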